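The source may report more compounds than this note shows. Statements on the series, on what has been measured and on what is new or still open speak of the compounds shown alone.

Compounds measured so far:
compound 1 `COn1c(-c2ccccc2)c(C=O)c2cc(C#N)c(C#N)cc21` — > 100000 nM
compound 2 `COc1ccc(-c2c(C=O)c3cc(C#N)c(C#N)cc3n2OC)cc1` — > 100000 nM

In an assay on isolated protein for inhibition of Amine oxidase [flavin-containing] B (Homo sapiens), read by fluorescence and spectrophotometry, with a stated time of 20 min (a higher number here means a weaker inhibitor, a lower number a stronger inhibitor), compound 1 gives > 100000 nM, which is a limit of the assay rather than a number. Compound 2 also returns a limit, > 100000 nM. The step that the two limits leave unreadable from compound 1 to compound 2, a methoxy in place of hydrogen on an aromatic carbon, therefore cannot be read, as both values sit at the same limit (the limit of > 100000 nM in this assay, at which 2 of the 2 values shown sit). Compound 1 thus stands only at a limit, with no readable position on the numbers shown.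

Compound 3 `COn1c(-c2ccccc2)c(CO)c2cc(C#N)c(C#N)cc21` differs from compound 1 by hydroxymethyl in place of formyl on an aromatic carbon. For the measured compounds named here, none of the measured steps touches this place, and the one measured step is itself unreadable, so no step bears on the change in size or direction. With compound 1 at > 100000 nM and nothing pointing to a gain, compound 3 is expected to remain at or near the limit, estimated at 150000 nM (range 50000 nM to 500000 nM), a step that the limit leaves unreadable from compound 1 to compound 3 that is an expectation only.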

Compound 3, half-maximal inhibitory concentration: > 100000 nM
Compound 3 gave a limit, no number (the forecaster's own chance of this, stated with the estimate: 80%); the middle value lies beyond the limit too.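

In this assay compound 3 gives > 100000 nM, a limit and not a number, so no step from compound 1 to compound 3 can be read: the limit of > 100000 nM in this assay, at which 3 of the 3 values shown sit.

The compounds shown leave open which change to the shared core, if any, would give a readable value.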